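The source may report more compounds than this note shows. Statements on the series, on what has been measured and on what is new or still open speak of the compounds shown alone.

Compound 2 `COc1cc2ccc(=O)oc2cc1OCC1CO1` holds the higher of the two numbers measured in a functional assay on HUVEC cells (Homo sapiens) for inhibition, read by MTT assay, with a stated time of 24 h, tested at 100 uM; on this read-out higher numbers stand for more inhibition of growth at the one concentration tested and lower numbers for less inhibition of growth; in this assay compound 2 gives 95.5%, whereas compound 1 `COc1cc2ccc(=O)oc2cc1OCCCCBr` gives 16.9%. Among the measured compounds shown here, the single measured step, a number 78.6 percentage points higher from compound 1 to compound 2 (beyond the scatter), is the only guide available. Compound 3 `COc1cc2ccc(=O)oc2cc1OCCNC(C)C` differs from compound 2 by (isopropylamino)methyl in place of oxiran-2-yl on a saturated chain carbon bound to an oxygen on an aromatic ring. For the measured compounds named here, no measured step shares this exact change; the one known step shows only that the group on this chain carbon shifted growth inhibition strongly. Because the large gain in a number 78.6 percentage points higher from compound 1 to compound 2 (beyond the scatter) came with the oxiran-2-yl that now leaves, a sizeable drop is expected, a number 60.5 percentage points lower from compound 2 to compound 3 (beyond the scatter), and compound 3 is estimated at 35%, within 10% to 75%.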

Compound 3, percent growth inhibition at one concentration: 0.1%
Compound 3: middle estimate off by 34.9 percentage points, on the high side; the measured number lies below the stated range.
By their numbers in this assay, from the lowest: compound 3; then compound 1; then compound 2.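

Exchanging oxiran-2-yl for (isopropylamino)methyl at this position gives a number 95.4 percentage points lower from compound 2 to compound 3 (beyond the scatter) in this assay and removes nearly all the growth inhibition seen with compound 2. The same amine chain also gives a number 16.8 percentage points lower from compound 1 to compound 3 (beyond the scatter), so it falls short of the bromo chain as well, and a nitrogen group here does not simply return the number to that of compound 1. Nothing available explains either drop.

On these data alone, it remains open whether a morpholine or a primary amine on this chain would behave like the isopropylamino group. As far as these compounds go, it is also open whether a longer chain carrying the oxiran-2-yl would keep the high number of compound 2.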